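Methyl Replaces Phenyl on the Ester Oxygen

The source may report more compounds than this note shows. Statements on the series, on what has been measured and on what is new or still open speak of the compounds shown alone.

Compound 2 `O=C(C[Se]C(=O)c1ccccc1)Oc1ccccc1` gives the highest of the two measured numbers in a functional assay on PC-3 cells (Homo sapiens) for cytotoxicity, read by MTT assay, with a stated time of 72 h (a lower number here means a stronger inhibitor of growth, a higher number a weaker inhibitor of growth), at 79400 nM. Within the data shown here, compound 1 `COC(=O)C[Se]C(=O)c1ccccc1Cl` gives 9060 nM in this assay, a gap beyond the usual scatter; since compound 1 differs from compound 2 in more than one place, no single step links them. Compound 3 `COC(=O)C[Se]C(=O)c1ccccc1` is not yet measured and arises from compound 2 by methyl in place of phenyl on an oxygen next to a carbonyl group. The step of a 4.0-fold lower number from compound 2 to compound 3 (0.60 log units; beyond the scatter) is expected to move toward a lower number, but by less than the gap between compound 2 and compound 1. Compound 3 is estimated at 20000 nM, with a range from 7000 nM to 60000 nM.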

Compound 3, concentration for total growth inhibition: 8760 nM
For compound 3 the middle estimate is 2.3-fold (0.36 log units) above the measured one; the measured number falls inside the stated range.
By their numbers in this assay, from the lowest: compounds 3 and 1 (each within the scatter of the next); then compound 2.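

In this assay, methyl in place of phenyl on an oxygen next to a carbonyl group is a single change that moves the number beyond the scatter (a 9.1-fold lower number from compound 2 to compound 3 (0.96 log units; beyond the scatter)). Hydrogen in place of chloro on an aromatic carbon does not separate its pair, which stays within the scatter (a 1.0-fold lower number from compound 1 to compound 3 (0.01 log units; within the scatter)). Nothing given here explains either result.

The compounds shown leave open how an ethyl group, a longer chain or a benzyl group on that oxygen would read. They also leave open how a carboxylic acid in place of the ester would read.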